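This account rests on a few compounds, and the source may have more. Where it says the series, first, only, none or still open, it means among the compounds named here.

Values in a functional assay on NCI-H23 cells (Homo sapiens) for cytotoxicity, read by colorimetric assay; a higher number here means a weaker inhibitor, a lower number a stronger inhibitor:
Compound 1 `Cc1ccc2c(c1)/C(=C1/Nc3ccccc3/C1=N\O)C(=O)N2Cc1ccc(/C=C/C(=O)NO)cc1`: 10 nM
Compound 2 `O=C(NO)c1ccc(CN2C(=O)/C(=C3\Nc4ccccc4\C3=N/O)c3cc(Cl)ccc32)cc1`: 50 nM
Compound 3 `O=C(NO)c1ccc(CN2C(=O)/C(=C3\Nc4ccccc4\C3=N/O)c3cc(F)ccc32)cc1`: 30 nM

Compound 3 at 30 nM lies within the scatter of compound 2. Compound 1 has a lower number, beyond the scatter of compound 3.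

Next is compound 4 `Cc1ccc2c(c1)/C(=C1/Nc3ccccc3/C1=N\O)C(=O)N2Cc1ccc(C(=O)NO)cc1`, with methyl in place of fluoro on an aromatic carbon. The closest measured step is a 1.7-fold lower number from compound 2 to compound 3 (0.22 log units; within the scatter), fluoro in place of chloro. Compound 1 also carries the methyl but differs from compound 4 elsewhere, so it does not isolate this change. No step beyond the scatter is expected in this assay. The expected change is a 1.2-fold lower number from compound 3 to compound 4 (0.08 log units; within the scatter). Compound 4 is estimated at 25 nM, with an expected range of 9 nM to 70 nM.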

Compound 4, half-maximal inhibitory concentration: 10 nM
The estimate for compound 4 lay 2.5-fold (0.40 log units) above the measured number; the measured number falls inside the stated range.
By their numbers in this assay, from the lowest: compounds 1 and 4 (each within the scatter of the next); then compounds 3 and 2 (each within the scatter of the next).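

In this assay methyl on this aromatic carbon stands apart from both halogens, with a 3.0-fold lower number from compound 3 to compound 4 (0.48 log units; beyond the scatter) and a 5.0-fold lower number from compound 2 to compound 4 (0.70 log units; beyond the scatter) while the swap between chloro and fluoro stayed within the scatter. With methyl in place, hydroxycarbamoyl for 2-(hydroxycarbamoyl)ethenyl gives no change at the digits printed from compound 1 to compound 4 (within the scatter) and so separates the two chains in no way here. Nothing measured on these compounds accounts for the methyl step.

On these data alone, whether methyl alone holds this gain remains open, since methoxy, an amine or a longer alkyl chain on this carbon would test it. Also open, as far as these compounds go, is whether the two chains stay matched with fluoro or chloro on the core.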